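Moving the chlorine on the benzylsulfanyl group

The compounds below may be only part of what the source reports. "The series", "measured", "known", "first", "only" and "open" are said of these compounds alone.

Of the compounds shown here, three have been measured in a functional assay on the whole organism (artery, strain albino) with Rattus norvegicus as the target, with a stated time of 60 min, at a dose of 10 mg/kg by the oral route; on this read-out lower numbers stand for less inhibition and higher numbers for more inhibition at the one dose given (going by the name of the read-out). Compound 1 `CC1=C(C(=O)Nc2ccc([N+](=O)[O-])cc2)C(c2ccc(Br)cc2)N=C(SCc2ccc(Cl)cc2)N1` gives 10.8%. Compound 2 `CC1=C(C(=O)Nc2ccc([N+](=O)[O-])cc2)C(c2cccc([N+](=O)[O-])c2)N=C(SCc2ccccc2)N1` gives 7.7%. Compound 3 `CC1=C(C(=O)Nc2ccc([N+](=O)[O-])cc2)C(c2cccc([N+](=O)[O-])c2)N=C(SCc2cccc(Cl)c2)N1` gives 8.2%. On these numbers compound 3 lies between the other two, and both gaps are within the scatter, so the three compounds cannot be told apart on this read-out.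

The unmeasured compound 4 `CC1=C(C(=O)Nc2ccc([N+](=O)[O-])cc2)C(c2cccc([N+](=O)[O-])c2)N=C(SCc2ccc(Cl)cc2)N1` differs from compound 3 in one place: 4-chlorophenyl in place of 3-chlorophenyl on a saturated chain carbon bound to a sulfur. For the measured compounds named here, the only single-point step among the measured compounds is a number 0.5 percentage points higher from compound 2 to compound 3 (within the scatter), which adds a chlorine rather than moving one and so bears on the present change only loosely. Compound 1 carries the same 4-chlorobenzyl group as compound 4 but a different aryl on the shared core, so its value can only be set next to that of compound 3, and the two lie within the scatter of each other.

With nothing in the measured set pointing beyond the scatter, the step of a number 0.8 percentage points higher from compound 3 to compound 4 (within the scatter) is expected to be small. Compound 4 is therefore estimated at 9%, with a range from 2% to 17% in this assay.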

Compound 4, a percentage reported as inhibition, in the whole organism at one dose (the size of the read-out at that dose, not a potency): 6.7%
The estimate for compound 4 lay 2.3 percentage points above the measured number; the measured number falls inside the stated range.
By their numbers in this assay, from the lowest: compounds 4, 2, 3 and 1 (each within the scatter of the next).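

In this assay, the 4-chlorophenyl in place of 3-chlorophenyl on a saturated chain carbon bound to a sulfur gives a number 1.5 percentage points lower from compound 3 to compound 4 (within the scatter) and thus shows that this move of the chlorine leaves no readable difference at this position. With the chlorine in the 4-chlorobenzyl form, the comparison with the unchlorinated benzyl group gives a number 1 percentage points lower from compound 2 to compound 4 (within the scatter) and stands with a number 0.5 percentage points higher from compound 2 to compound 3 (within the scatter) as a second case in which adding chloro in place of hydrogen on an aromatic carbon cannot be told from the scatter. The set also now holds its first single-place change at the other site, since 3-nitrophenyl in place of 4-bromophenyl on a saturated ring carbon gives a number 4.1 percentage points lower from compound 1 to compound 4 (within the scatter) and that exchange is likewise not separated from the scatter.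

The data offer nothing that bears on these numbers. Still open, on these data alone, is whether any change at the sulfur, such as an amine or a carboxylic acid on the benzyl ring or a longer chain in place of the benzyl group, would give a step beyond the scatter in this assay at all.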